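This account rests on a few compounds, and the source may have more. Where it says the series, first, only, none or still open, it means among the compounds named here.

Measured so far in a functional assay on HEK293 cells for antagonist activity at thromboxane A2 receptor (Homo sapiens), read by fluorescence and calcium flux; on this read-out higher numbers stand for weaker inhibition and lower numbers for stronger inhibition:
compound 1, `CC(C)NC(=O)NS(=O)(=O)c1cc(C#N)ccc1Oc1ccc(Cl)cc1`, gives 8490 nM;
compound 2, `CC(C)(C)NC(=O)NS(=O)(=O)c1cc(C#N)ccc1Oc1ccc(Cl)cc1`, gives 5270 nM.

Of these two numbers compound 1 carries the higher one, but compound 2 stands only a 1.6-fold lower number from compound 1 to compound 2 (0.21 log units; within the scatter), a gap within the scatter, so the two compounds are not really separated. That single measured step concerns a saturated chain carbon bound to the amide-type nitrogen and leaves the rest of the shared core untouched.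

Compound 3, `Cc1cccc(Nc2ccc(C#N)cc2S(=O)(=O)NC(=O)NC(C)C)c1`, differs from compound 1 in a different place: (3-methylphenyl)amino in place of 4-chlorophenoxy on an aromatic carbon. Within the data shown here, no measured pair alters this part of the core, so nothing measured bears directly on the step, and no direction can be read from the data. The expectation for this assay is therefore a step of a 1.4-fold lower number from compound 1 to compound 3 (0.15 log units; within the scatter), with a wide range around it to reflect the lack of any guiding measurement. Compound 3 is estimated at 6000 nM, expected to fall between 1000 nM and 30000 nM.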

Compound 3, half-maximal inhibitory concentration: 9110 nM
Compound 3: middle estimate off by 1.5-fold (0.18 log units), on the low side; low and high end bracket the measured number.
By their numbers in this assay, from the lowest: compounds 2, 1 and 3 (each within the scatter of the next).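

Among these compounds, this is the first measured change on this aromatic carbon, which sits ortho to a large group and para to a cyano group, and in this assay exchanging 4-chlorophenoxy for (3-methylphenyl)amino gives a 1.1-fold higher number from compound 1 to compound 3 (0.03 log units; within the scatter), so compound 1 and compound 3 cannot be told apart. The swap is not a small one: the oxygen and the chlorine leave, a nitrogen and a methyl enter, and the entering group has 1 hydrogen-bond donor where the leaving group has 0, yet this read-out does not separate the pair, so the position accepts at least this one exchange of aryl groups with no change beyond the scatter. Nothing measured here offers a reason for this outcome.

Since several features change together in this one step, the compounds shown cannot say what the linking atom and the ring substituents each contribute, and a pair such as unsubstituted phenoxy against phenylamino would be needed to pull them apart. On these data alone, it also stays open whether this carbon tolerates groups without an aromatic ring, such as a methoxy group, a dimethylamino group or a carboxylic acid.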